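The compounds below may be only part of what the source reports. "The series", "measured", "known", "first", "only" and "open" are said of these compounds alone.

Measured compounds:
compound 1 `O=C(Nc1ccc(Oc2ccc(-c3nccs3)cc2)cc1)Nc1ccc(F)c(Cl)c1` — 43.9%
compound 2 `CC(=O)Oc1sccc1NC(=O)Nc1ccc(Oc2ccc(-c3nccs3)cc2)cc1` — 11%
compound 3 `O=C(Nc1ccc(Oc2ccc(-c3ncc[nH]3)cc2)cc1)Nc1ccc(F)c(Cl)c1` — 4.2%

All three were run in a functional assay on MDA-MB-231 cells (Homo sapiens) for inhibition, read by MTT assay and WST assay, with a stated time of 72 h, tested at 10 uM; a higher number here means more inhibition of growth at the concentration tested, a lower number less inhibition of growth. Compound 1 is the highest of the three in this assay. The change from compound 1 to compound 2 is 2-acetoxythiophen-3-yl in place of 3-chloro-4-fluorophenyl on an amide-type nitrogen and it gave a number 32.9 percentage points lower from compound 1 to compound 2 (beyond the scatter). The cores of compound 1 and compound 3 differ by 1H-imidazol-2-yl in place of 1,3-thiazol-2-yl on an aromatic carbon, which gave a number 39.7 percentage points lower from compound 1 to compound 3 (beyond the scatter). Compound 2 and compound 3 lie within the scatter of each other.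

Compound 4 `CC(=O)Oc1sccc1NC(=O)Nc1ccc(Oc2ccc(-c3ncc[nH]3)cc2)cc1` has not been measured. It differs from compound 3 by 2-acetoxythiophen-3-yl in place of 3-chloro-4-fluorophenyl on an amide-type nitrogen. The place is the same word for word as in the change from compound 1 to compound 2, so this is the same change made on the core of compound 3. The earlier step was large, but compound 3 already gives a low number, so a far smaller step is expected here, roughly a number 1.2 percentage points lower from compound 3 to compound 4 (within the scatter), because compound 3 gives only 4.2% in this assay. Compound 4 is expected to give about 3%, between -8% and 15%.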

Compound 4, percent growth inhibition at one concentration: -1.46%
Beside the measured number, compound 4's estimate is 4.5 percentage points above it; low and high end bracket the measured number.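

On the core of compound 3, 2-acetoxythiophen-3-yl in place of 3-chloro-4-fluorophenyl on an amide-type nitrogen in this assay gives a number 5.7 percentage points lower from compound 3 to compound 4 (within the scatter), so the size of this step does not carry over from the core of compound 1: the same change on two cores in this assay, a number 32.9 percentage points lower (beyond the scatter) from compound 1 to compound 2 and a number 5.7 percentage points lower (within the scatter) from compound 3 to compound 4, 27.2 percentage points apart, beyond the scatter of two such steps

The other change, 1H-imidazol-2-yl in place of 1,3-thiazol-2-yl on an aromatic carbon, gives a number 12.5 percentage points lower from compound 2 to compound 4 (beyond the scatter), and it too depends on what else the compound carries: the same change on two cores in this assay, a number 39.7 percentage points lower (beyond the scatter) from compound 1 to compound 3 and a number 12.5 percentage points lower (beyond the scatter) from compound 2 to compound 4, 27.2 percentage points apart, beyond the scatter of two such steps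

Both comparisons rest on the same four compounds, so they show that the two changes do not add up here, but they do not show whether this holds on other cores or whether the smaller steps merely reflect the low starting numbers, such as compound 3 at 4.2%.

Open, going by these compounds, is whether a plain phenyl or a 4-fluorophenyl on the amide-type nitrogen keeps the number of compound 1. Also open, on these data alone, is whether a 1,3-oxazol-2-yl or a simple amine on the aromatic carbon behaves like 1,3-thiazol-2-yl or like 1H-imidazol-2-yl.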